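The source may report more compounds than this note shows. Statements on the series, on what has been measured and on what is new or still open speak of the compounds shown alone.

The study turns on a functional assay on MDA-MB-231 cells (Homo sapiens) for antiproliferative activity, read by MTT assay, with a stated time of 72 h; on this read-out higher numbers stand for weaker inhibition and lower numbers for stronger inhibition. Compound 1, `COc1cc(CCc2ccc(Br)cc2)cc(OC)c1O`, gives > 25000 nM, which is a limit of the assay rather than a measured number. Compound 2, `COc1cc(CCc2cccc(F)c2)cc(OC)c1O`, likewise gives > 25000 nM, again a limit and not a number. Compound 3, `COc1ccc(CCc2ccccn2)cc1OC`, gives 10500 nM. Compound 2 thus stands at the limit of > 25000 nM in this assay, at which 2 of the 3 values shown sit, so that for compound 2 only a bound is known and no point value. Compound 4, `COc1cc(CCc2ccccc2)cc(OC)c1O`, is the next candidate; it differs from compound 2 by hydrogen in place of fluoro on an aromatic carbon. For the measured compounds named here, no step between two measured compounds is available to calibrate how much such a change moves the read-out, so the size of the step must be judged without a precedent. The change is expected to bring no step beyond the scatter in this assay, in either direction. Compound 4 is therefore estimated at 25000 nM, with a range from 8000 nM to 60000 nM. This estimate implies a step of a number no higher from compound 2 to compound 4 (the limit leaves the size open), expected to lie within the scatter, and there is a fair chance the assay will again report only a limit for compound 4.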

Compound 4, half-maximal inhibitory concentration: > 25000 nM
Compound 4: no number, only a limit; the forecaster's own chance of this, stated with the estimate: 60%; the middle value lies on the limit itself.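

For the compounds shown here, compound 4 sits at a limit of the assay, as do compound 1 and compound 2, so no step from either of them to compound 4 can be read: the limit of > 25000 nM in this assay, at which 3 of the 4 values shown sit. The compounds shown leave open whether hydrogen, fluoro or bromo on an aromatic carbon makes any difference in this assay.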